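The compounds below may be only part of what the source reports. "The series", "measured", "known", "first", "only" and "open" are said of these compounds alone.

In a functional assay on MCF7 cells (Homo sapiens) for cytotoxicity, read by MTT assay, with a stated time of 72 h (a higher number here means a weaker inhibitor of growth, a lower number a stronger inhibitor of growth), compound 1 `N#CSCN1C(=O)c2ccccc2C1=O` gives 48100 nM. Altering compound 1 by a group of 3 heavy atoms (1 carbon, 1 nitrogen, 1 selenium; no ring) in place of a group of 3 heavy atoms (1 carbon, 1 nitrogen, 1 sulfur; no ring), on a saturated chain carbon bound to an amide-type nitrogen in a ring yields compound 2 `N#C[Se]CN1C(=O)c2ccccc2C1=O`, which in this assay gives 15400 nM; the change made a 3.1-fold lower number from compound 1 to compound 2 (0.49 log units; beyond the scatter). Compound 3 `N#CSCc1ccc(-n2cccc2)cc1` has a different core, and how the two cores differ is not broken down here. In this assay compound 3 gives 8200 nM. Compound 4 `N#C[Se]Cc1ccc(-n2cccc2)cc1` is not yet measured. It differs from compound 3 by a group of 3 heavy atoms (1 carbon, 1 nitrogen, 1 selenium; no ring) in place of a group of 3 heavy atoms (1 carbon, 1 nitrogen, 1 sulfur; no ring), on a saturated chain carbon bound to an aromatic carbon, the same kind of change as before, though here the place is a saturated chain carbon bound to an aromatic carbon rather than one bound to an amide-type nitrogen in a ring. This change is expected to make a 2.5-fold lower number from compound 3 to compound 4 (0.40 log units; beyond the scatter), resting on the one earlier case, where it made a 3.1-fold lower number from compound 1 to compound 2 (0.49 log units; beyond the scatter). Compound 4 is therefore estimated at 3300 nM, likely between 1500 nM and 8000 nM.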

Compound 4, concentration for 50% growth inhibition: 2400 nM
Compound 4: middle estimate off by 1.4-fold (0.14 log units), on the high side, within the range that was stated.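

In this assay, putting selenium in place of sulfur in the cyanosulfanyl group gives a 3.4-fold lower number from compound 3 to compound 4 (0.53 log units; beyond the scatter). The change therefore carried over with much the same size on these two different cores: the same change on two cores in this assay, a 3.1-fold lower number (0.49 log units; beyond the scatter) from compound 1 to compound 2 and a 3.4-fold lower number (0.53 log units; beyond the scatter) from compound 3 to compound 4, 1.1-fold (0.04 log units) apart, within the scatter of two such steps

Two cores in one cell assay do not show that the step would hold on every core in the series, and they do not explain why the selenium compounds give the lower numbers. The compounds shown leave open whether the same step appears with a longer chain in place of the saturated chain carbon. They also leave open whether it appears on a core carrying an amine or a carboxylic acid.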